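This account rests on a few compounds, and the source may have more. Where it says the series, first, only, none or still open, it means among the compounds named here.

- compound 1 `CN1CC=C(c2c(O)cc(O)c3c(=O)cc(-c4ccc(Sc5nc6ccccc6[nH]5)cc4)oc23)CC1` gives 293 nM
- compound 2 `CN1CC=C(c2c(O)cc(O)c3c(=O)cc(-c4ccc(Sc5nc6ccccc6n5C)cc4Cl)oc23)CC1` gives 181 nM
- compound 3 `CN1CC=C(c2c(O)cc(O)c3c(=O)cc(-c4ccc(Sc5nc6ccccc6n5C)cc4)oc23)CC1` gives 219 nM

In a functional assay on HCT-116 cells (Homo sapiens) for antiproliferative activity, read by luminescence, with a stated time of 72 h (on this read-out higher numbers stand for weaker inhibition and lower numbers for stronger inhibition), compound 3 sits among these numbers with nothing to separate it from the other two, as both its steps lie within the scatter. Compound 4 `CN1CC=C(c2c(O)cc(O)c3c(=O)cc(-c4ccc(Sc5nc(-c6ccccc6)c[nH]5)cc4)oc23)CC1` changes one group of compound 3: 4-phenyl-1H-imidazol-2-yl in place of 1-methyl-1H-benzimidazol-2-yl on a sulfur. The nearest guide is a 1.3-fold lower number from compound 1 to compound 3 (0.13 log units; within the scatter) for methyl in place of hydrogen on an aromatic nitrogen. The other guide is a 1.2-fold higher number from compound 2 to compound 3 (0.08 log units; within the scatter) for hydrogen in place of chloro on an aromatic carbon. Neither step replaces the whole group on the sulfur, so the data hold no direct measure of this change. Going by these small steps, no shift beyond the scatter is expected in this assay for this swap. The expected move is a 1.2-fold higher number from compound 3 to compound 4 (0.07 log units; within the scatter) and the uncertainty stays wide. For compound 4 the estimated value is 260 nM with an expected range from 90 nM to 750 nM overall.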

Compound 4, half-maximal inhibitory concentration: 173 nM
Compound 4: middle estimate off by 1.5-fold (0.18 log units), on the high side, and the stated range covers the measured number.
By their numbers in this assay, from the lowest: compounds 4, 2, 3 and 1 (each within the scatter of the next).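

In this assay, the whole group on the sulfur can be exchanged without leaving the scatter: 4-phenyl-1H-imidazol-2-yl in place of 1-methyl-1H-benzimidazol-2-yl gives (a 1.3-fold lower number from compound 3 to compound 4 (0.10 log units; within the scatter)), and in place of 1H-benzimidazol-2-yl it gives (a 1.7-fold lower number from compound 1 to compound 4 (0.23 log units; within the scatter)). The entering group also carries a hydrogen-bond donor that 1-methyl-1H-benzimidazol-2-yl lacks, and the number still stays within the scatter. Nothing measured here bears on the reason for this result. The compounds shown leave open whether a group without an aromatic ring on the sulfur, such as a short alkyl chain or a carboxylic acid, would keep the number in this range.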